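This account rests on a few compounds, and the source may have more. Where it says the series, first, only, none or still open, it means among the compounds named here.

Measured so far:
compound 1, `COc1cc(C2=NN(C(C)=O)C(c3c(Cl)cccc3Cl)O2)cc(OC)c1OC`, 5.1%
compound 2, `COc1cc(C2=NN(C(C)=O)C(c3cccc(OC)c3OC)O2)cc(OC)c1OC`, 35%
compound 3, `COc1ccc(OC)c(C2OC(c3cc(OC)c(OC)c(OC)c3)=NN2C(C)=O)c1`, 37.2%

In a functional assay on PC-3 cells (Homo sapiens) for antiproliferative activity, read by MTT assay, tested at 1 uM (on this read-out higher numbers stand for a stronger effect at the one concentration tested and lower numbers for a weaker effect), compound 3 gives 37.2%, the highest of the three numbers. Its nearest neighbour is compound 2, which gives 35%; these two values lie within the scatter of each other, so no order between them can be claimed. The one clear gap is to compound 1, which gives 5.1%.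

Compound 4, `COc1cc(C2=NN(C(C)=O)C(c3ccc(C(F)(F)F)cc3)O2)cc(OC)c1OC`, has not yet been measured. It differs from compound 3 in one place: 4-(trifluoromethyl)phenyl in place of 2,5-dimethoxyphenyl on a saturated ring carbon.

The measured steps that bear on this position are a number 32.1 percentage points higher from compound 1 to compound 3 (beyond the scatter), a number 29.9 percentage points higher from compound 1 to compound 2 (beyond the scatter) and a number 2.2 percentage points higher from compound 2 to compound 3 (within the scatter). Swapping one dimethoxyphenyl for another changed nothing beyond the scatter, whereas replacing the dichlorophenyl by either dimethoxyphenyl raised the number clearly. Within the data shown here, no measured compound carries a phenyl with no acceptors at this carbon, so the step to compound 4 cannot be read from a direct precedent. A downward step is therefore expected, a number 19.2 percentage points lower from compound 3 to compound 4 (beyond the scatter), with wide uncertainty. Compound 4 is estimated at 18%, in a range from 3% to 42%.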

Compound 4, a percentage reported as inhibition, at one concentration (the size of the read-out at that concentration, not a potency): -11%
Compound 4: the middle estimate sits 29 percentage points above what was measured; the measured number lies below the stated range.
By their numbers in this assay, from the lowest: compound 4; then compound 1; then compounds 2 and 3 (each within the scatter of the next).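

In this assay, putting 4-(trifluoromethyl)phenyl on the saturated ring carbon takes the read-out down sharply from either dimethoxyphenyl compound, with a number 48.2 percentage points lower from compound 3 to compound 4 (beyond the scatter) and a number 46 percentage points lower from compound 2 to compound 4 (beyond the scatter). The change also falls past the earlier low point at this carbon, with a number 16.1 percentage points lower from compound 1 to compound 4 (beyond the scatter), so 2,6-dichlorophenyl did not mark the bottom of the range here, and compound 4 gives -11%, a number below zero. Across the four compounds, the two dimethoxyphenyl groups sit high and the two halogen-bearing groups sit low, with no compound going against that split, yet nothing measured on these groups accounts for it.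

The compounds shown leave open whether the low number follows from the trifluoromethyl group itself or from the loss of the methoxy groups, a question that a plain phenyl or a 4-methoxyphenyl at this carbon would help to separate. On these data alone, it also remains open whether the number depends on where the substituents sit on the phenyl ring, and how an amine or a hydroxyl group on that ring would behave.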